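Replacing the 2,4-difluorobenzyl group of compound 2

This account rests on a few compounds, and the source may have more. Where it says the series, first, only, none or still open, it means among the compounds named here.

Measured so far in an ADME assay on the whole organism (Rattus norvegicus, strain Sprague-Dawley) for pharmacokinetics, read by LC-MS, at a dose of 5 mg/kg by the oral route; on this read-out higher numbers stand for higher exposure at the dose given and lower numbers for lower exposure:
- compound 1 `Cc1cccc(F)c1CN1CCc2cc(-c3c(C)nc(C)c([C@H](OC(C)(C)C)C(=O)O)c3N3CCC(C)(C)CC3)ccc2C1` gives 9630 ng.h/mL
- compound 2 `Cc1nc(C)c([C@H](OC(C)(C)C)C(=O)O)c(N2CCC(C)(C)CC2)c1-c1ccc2c(c1)CCN(Cc1ccc(F)cc1F)C2` gives 4420 ng.h/mL

Compound 2 holds the lower of the two numbers. For the measured compounds named here, its nearest and only neighbour is compound 1, and the single measured step is a 2.2-fold lower number from compound 1 to compound 2 (0.34 log units; beyond the scatter), a modest move beyond the scatter. That step only exchanges one substituted phenyl group for another, so it bears on the next change loosely.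

Compound 3 `Cc1nc(C)c([C@H](OC(C)(C)C)C(=O)O)c(N2CCC(C)(C)CC2)c1-c1ccc2c(c1)CCN(c1nccc(-c3cnccn3)n1)C2` loses the 2,4-difluorobenzyl and gains a group with no common name, on an amine nitrogen in a ring (a group of 12 heavy atoms (8 carbon, 4 nitrogen; 2 six-membered aromatic rings with 2 hetero atoms each) in place of a group of 9 heavy atoms (7 carbon, 2 fluorine; one six-membered aromatic ring of carbon only), on an amine nitrogen in a ring). Going by the values given here, this exchange is much larger than the measured one, and no measured compound carries the entering group. A step at least as large as the modest one seen so far is therefore expected in this assay, with a lower number taken as only slightly likelier than a higher one. The expected step is a 1.8-fold lower number from compound 2 to compound 3 (0.25 log units; within the scatter), and it is uncertain. For compound 3 the estimated value is 2500 ng.h/mL, with an expected range of 600 ng.h/mL to 9000 ng.h/mL.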

Compound 3, area under the concentration-time curve: 15100 ng.h/mL
Compound 3: middle estimate off by 6.0-fold (0.78 log units), on the low side, outside the stated range (above it).
By their numbers in this assay, from the lowest: compound 2; then compounds 1 and 3 (each within the scatter of the next).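

In this assay, the amine nitrogen in a ring accepts a group with no benzyl chain carbon, and the exchange of 2,4-difluorobenzyl for the group of 12 heavy atoms gives a 3.4-fold higher number from compound 2 to compound 3 (0.53 log units; beyond the scatter). Set against the 2-fluoro-6-methylbenzyl group of compound 1, the same entering group gives a 1.6-fold higher number from compound 1 to compound 3 (0.20 log units; within the scatter), so the two aromatic rings with 2 hetero atoms each, carrying 4 hydrogen-bond acceptors, are tolerated here without a measurable difference from the better of the two benzyl groups. Nothing measured alongside these numbers accounts for the gain over compound 2.

The entering group differs from both benzyl groups in its link to the nitrogen, its ring count and its ring atoms all at once, so the compounds shown do not tell which of these features goes with the step, and a plain phenyl group bound directly to the same nitrogen would help separate them. A single exposure number at one oral dose also leaves open whether the change acts through the amount absorbed or through the rate of removal from the body.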